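Triterpenoid ester analogues tested for antiproliferative activity

A few compounds are considered here, and "the series" means these few. Any claim that something is new, unique, unknown or untested is made for them only; others in the source may bear on it.

The series rests on a shared core carrying an acyl or oxime substituent on one ring and differing in the hydrocarbon portion at the far end. Compound 1 `CC1=CC[C@H]2[C@H](CC[C@]2(C)O)C(C)(C)[C@@H]1CC[C@H]1[C@]2(C)CC[C@H](OC(=O)c3ccc(C)cc3)C(C)(C)O[C@H]2CC[C@@]1(C)O` bears a (4-methylphenyl)carbonyl ester; compound 2 `CC1=CC[C@H]2[C@@H]1CC=C(C)[C@@H](CC[C@H]1[C@]3(C)CC[C@H](OC(=O)c4ccc(C)cc4)C(C)(C)O[C@H]3CC[C@@]1(C)O)C2(C)C` has the same ester on a rearranged hydrocarbon portion; compound 3 `CC1=CC[C@H]2[C@H](CC[C@]2(C)O)C(C)(C)[C@@H]1CC[C@H]1[C@]2(C)CC/C(=N/OCc3ccccc3)C(C)(C)O[C@H]2CC[C@@]1(C)O` carries a benzyloxime in place of the ester. In a functional assay on MDA-MB-231 cells (Homo sapiens) for antiproliferative activity, read by MTT assay, with a stated time of 72 h (a lower number here means a stronger inhibitor, a higher number a weaker inhibitor), compound 1 gives 33400 nM. In this assay compound 2 gives 32700 nM, and in this assay compound 3 gives 38200 nM. All three numbers lie within the scatter of one another, so compound 1 stands neither apart from compound 2 nor from compound 3; the three are indistinguishable on these data.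

Compound 4 `CC1=CC[C@H]2[C@H](CC[C@]2(C)O)C(C)(C)[C@@H]1CC[C@H]1[C@]2(C)CC[C@H](OC(=O)c3ccco3)C(C)(C)O[C@H]2CC[C@@]1(C)O` is the next variant and differs from compound 1 only in the ester: furan-2-yl in place of 4-methylphenyl on a carbonyl carbon. Within the data shown here, no step between measured compounds isolates this kind of exchange, so the expectation leans on the flat picture given by compound 1, compound 2 and compound 3. The change from compound 1 to compound 4 is expected to produce a step of a 1.0-fold higher number from compound 1 to compound 4 (0.02 log units; within the scatter) in this assay, which amounts to none beyond the scatter. Compound 4 is therefore estimated to give 35000 nM in this assay, with a likely range from 15000 nM to 80000 nM.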

Compound 4, half-maximal inhibitory concentration: 14000 nM
Beside the measured number, compound 4's estimate is 2.5-fold (0.40 log units) above it, outside the stated range (below it).
By their numbers in this assay, from the lowest: compound 4; then compounds 2, 1 and 3 (each within the scatter of the next).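

Compound 4 shows that the ester on the shared core is a place where a single exchange can move the number in this assay: furan-2-yl in place of 4-methylphenyl on a carbonyl carbon gives a 2.4-fold lower number from compound 1 to compound 4 (0.38 log units; beyond the scatter) and counts as a modest step. Among these compounds, compound 1, compound 2 and compound 3 had given a flat picture, with no step to show whether the aromatic group of the ester mattered, and this pair now shows that the read-out responds to that group. No measurement shown here accounts for the step.

With a single exchange shown at this position, it remains open whether the step belongs to the furan-2-yl ring as a whole, to its ring oxygen, or to the loss of the 4-methylphenyl group. Going by these compounds, a thiophen-2-yl or unsubstituted phenyl ester, an acetyl ester or an ester carrying an amine would help separate these readings, and it is equally open whether the furan-2-yl ester would give a similar step on the rearranged hydrocarbon portion of compound 2.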